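From hydroxymethyl to acetamidomethyl

This account rests on a few compounds, and the source may have more. Where it says the series, first, only, none or still open, it means among the compounds named here.

Among the measured compounds shown here, in a physicochemical assay for solubility, read by LC-MS, with a stated time of 16 h, at pH 7 (a higher number here means a more soluble compound, a lower number a less soluble compound), compound 2 `CCCC[S+]([O-])c1sc2nc(-c3nccs3)cc(-c3ccc(CO)cc3)c2c1N` gives 12.5 ug/mL, the highest number of the three measured so far. Compound 1 `CCCC[S+]([O-])c1sc2nc(-c3nccs3)cc(-c3ccc(COC(=O)CN(C)C)cc3)c2c1N` gives 6 ug/mL, and compound 3 `CCCC[S+]([O-])c1sc2nc(-c3nccs3)cc(-c3cnc(C)[nH]3)c2c1N` gives 4.1 ug/mL. Compound 4 `CCCC[S+]([O-])c1sc2nc(-c3nccs3)cc(-c3ccc(CNC(C)=O)cc3)c2c1N` is still unmeasured. It differs from compound 2 in one place: acetamido in place of hydroxy on a saturated chain carbon bound to an aromatic carbon, (acetamido in place of hydroxy on a saturated chain carbon bound to an aromatic carbon).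

Two measured steps offer guidance. The closer one is a 2.1-fold higher number from compound 1 to compound 2 (0.32 log units; beyond the scatter), where hydrogen replaces ((dimethylamino)methyl)carbonyl on the oxygen of that same chain. Read in reverse, it means that a larger group at this spot came with a lower number. The more distant one is a 3.0-fold lower number from compound 2 to compound 3 (0.48 log units; beyond the scatter), where 2-methyl-1H-imidazol-5-yl replaces the whole 4-(hydroxymethyl)phenyl. Both steps are modest, and compound 2 sits above both neighbours, so a modest fall is expected here too. The expected change is a 2.1-fold lower number from compound 2 to compound 4 (0.32 log units; beyond the scatter). For compound 4 the estimated value in this assay is 6 ug/mL, with an expected range of 2.5 ug/mL to 14 ug/mL.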

Compound 4, solubility: 2.16 ug/mL
Estimate against measurement, compound 4: 2.8-fold (0.44 log units) above, outside the stated range (below it).
By their numbers in this assay, from the lowest: compounds 4, 3 and 1 (each within the scatter of the next, the first and the last beyond it); then compound 2.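

At the saturated chain carbon bound to an aromatic carbon, acetamido in place of hydroxy gives a 5.8-fold lower number from compound 2 to compound 4 (0.76 log units; beyond the scatter) in this assay, so both larger groups seen on this carbon now come with lower numbers than hydroxy. The two larger groups also differ from each other: acetamido in place of (((dimethylamino)methyl)carbonyl)oxy gives a 2.8-fold lower number from compound 1 to compound 4 (0.44 log units; beyond the scatter) for this read-out. Acetamido has the same hydrogen-bond donor and acceptor counts as hydroxy and no net charge, so matching those counts did not keep the number up.

No measurement shown explains these falls. Going by these compounds, it also stays open whether a primary amine or a carboxylic acid on this carbon would give a number closer to that of the hydroxy compound or one lower still.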